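The compounds below may be only part of what the source reports. "The series", "measured", "known", "first", "only" and "open" are said of these compounds alone.

Compound 3 `CCCCc1ccc(Cn2ccc3cc(/C(C)=C/C(=O)Nc4ccccc4OCCCC(=O)O)ccc32)cc1` stands second highest of the three numbers in an assay on Prostate gland for inhibition of steroid 5-alpha-reductase (Rattus norvegicus); on this read-out lower numbers stand for stronger inhibition and higher numbers for weaker inhibition: compound 3 gives 100 nM, compound 2 `CCCCCn1ccc2cc(/C(C)=C/C(=O)Nc3ccccc3OCCCC(=O)O)ccc21` gives 23 nM, and compound 1 `C/C(=C\C(=O)Nc1ccccc1OCCCC(=O)O)c1ccc2c(ccn2C)c1` gives 780 nM. The measured steps are a 34-fold lower number from compound 1 to compound 2 (1.53 log units; beyond the scatter), a 7.8-fold lower number from compound 1 to compound 3 (0.89 log units; beyond the scatter) and a 4.3-fold higher number from compound 2 to compound 3 (0.64 log units; beyond the scatter). Compound 4 `COc1ccc(Cn2ccc3cc(/C(C)=C/C(=O)Nc4ccccc4OCCCC(=O)O)ccc32)cc1` differs from compound 3 by methoxy in place of butyl on an aromatic carbon. Within the data shown here, none of the measured steps alters a substituent on that ring; all three change what sits on the saturated chain carbon bound to the aromatic nitrogen. Among the measured compounds shown here, the only guidance is indirect: compound 3 is separated from compound 2 by a 4.3-fold higher number from compound 2 to compound 3 (0.64 log units; beyond the scatter), and from compound 1 by a 7.8-fold lower number from compound 1 to compound 3 (0.89 log units; beyond the scatter), which shows that the group on that chain carbon matters, while a methoxy against a butyl on the outer ring is untested here. A modest weakening is expected, a 2.0-fold higher number from compound 3 to compound 4 (0.30 log units; within the scatter), with wide uncertainty in either direction. Compound 4 is estimated at 200 nM in this assay, with a range from 80 nM to 600 nM.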

Compound 4, half-maximal inhibitory concentration: 480 nM
Estimate against measurement, compound 4: 2.4-fold (0.38 log units) below; measured number inside the range.
By their numbers in this assay, from the lowest: compound 2; then compound 3; then compounds 4 and 1 (each within the scatter of the next).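

In this assay, among these compounds, the substituent on the outer ring now proves to matter: methoxy in place of butyl on this aromatic carbon gives a 4.8-fold higher number from compound 3 to compound 4 (0.68 log units; beyond the scatter) and is the first change measured at this position. Compared with butyl on the saturated chain carbon bound to the aromatic nitrogen, 4-methoxyphenyl gives a 21-fold higher number from compound 2 to compound 4 (1.32 log units; beyond the scatter), while compared with hydrogen there it gives a 1.6-fold lower number from compound 1 to compound 4 (0.21 log units; within the scatter), so the larger group with methoxy shows no gain beyond the scatter over the unextended chain. Nothing available explains either the loss with methoxy or the missing gain over hydrogen.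

Methoxy differs from butyl in both chain length and the presence of oxygen, so these compounds do not separate the two changes. A butoxy group on the same carbon would test chain length with the oxygen kept, and a dimethylamino group would test a nitrogen there.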